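A few compounds are considered here, and "the series" means these few. Any claim that something is new, unique, unknown or untested is made for them only; others in the source may bear on it.

In a functional assay on A549 cells (Homo sapiens) for inhibition, with a stated time of 72 h (on this read-out higher numbers stand for weaker inhibition and lower numbers for stronger inhibition), compound 1 `Cc1ccc(NC(=O)Nc2nc(Nc3ccccc3)cc(Sc3c[nH]c4ccccc34)n2)cc1` gives 23500 nM. Compound 2 `Cc1cc(Cl)ccc1NC(=O)Nc1nc(Nc2ccccc2)cc(Sc2c[nH]c3ccccc23)n1` is reported only as a limit of the assay, > 50000 nM. Going by the values given here, the one measured step, an at least 2.1-fold higher number from compound 1 to compound 2 (0.32 log units; beyond the scatter), lies beyond the scatter and concerns the group on the amide-type nitrogen, with 4-chloro-2-methylphenyl in place of 4-methylphenyl. Compound 3 `Cc1cc(Cl)ccc1NC(=O)Nc1nc(Sc2c[nH]c3ccccc23)cc(N2CCN(c3ccccn3)CC2)n1` keeps that group and changes elsewhere: 4-(pyridin-2-yl)piperazin-1-yl in place of anilino on an aromatic carbon, with 4-(pyridin-2-yl)piperazin-1-yl in place of anilino on an aromatic carbon. Among the compounds with values here, no measured step touches this site, so the earlier step is only a weak guide. Within the data shown here, the expectation therefore leans on compound 1, at 23500 nM, the only true number available. The expected step in this assay is an at least 2.0-fold lower number from compound 2 to compound 3 (0.30 log units; that floor lies within the scatter), a modest one toward stronger inhibition, and its size is uncertain. For compound 3 the estimate is 25000 nM, with an expected range of 5000 nM to 60000 nM.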

Compound 3, half-maximal inhibitory concentration: > 50000 nM
Compound 3: no number, only a limit (the forecaster's own chance of this, stated with the estimate: 35%); at least 2.0-fold (0.30 log units) between middle value and limit.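

In this assay compound 3 is reported only as a limit of the assay, > 50000 nM. Going by these compounds alone, compound 2 sits at the same limit, so no step between compound 2 and compound 3 can be read: the limit of > 50000 nM in this assay, at which 2 of the 3 values shown sit. The compounds shown leave open whether 4-(pyridin-2-yl)piperazin-1-yl in place of anilino changes inhibition in either direction.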